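A few compounds are considered here, and "the series" means these few. Any claim that something is new, unique, unknown or untested is made for them only; others in the source may bear on it.

Working notes on the series. The shared core is shown by compound 1 `COC(=O)NC[C@@H]1CCCc2cc(S(=O)(=O)c3cccc(F)c3)ccc21`; compound 2 `O=C(CO)NC[C@@H]1CCCc2cc(S(=O)(=O)c3cccc(F)c3)ccc21` and compound 3 `NS(=O)(=O)NC[C@@H]1CCCc2cc(S(=O)(=O)c3cccc(F)c3)ccc21` differ from it only in the group on the amine nitrogen. In an assay on isolated protein for displacement of a labelled ligand from 5-hydroxytryptamine receptor 6 (Homo sapiens) (a lower number here means a stronger inhibitor, a higher number a weaker inhibitor), compound 1 gives 1.59 nM, compound 2 gives 0.1 nM and compound 3 gives 0.126 nM. Compound 2 holds the lowest of the three numbers: a 1.3-fold higher number from compound 2 to compound 3 (0.10 log units; within the scatter) lies within the scatter, whereas a 16-fold lower number from compound 1 to compound 2 (1.20 log units; beyond the scatter) and a 13-fold lower number from compound 1 to compound 3 (1.10 log units; beyond the scatter) are both large.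

Compound 4 `O=C(CO)NC[C@@H]1CCCc2cc(S(=O)(=O)c3cccc(F)c3)cc(F)c21` carries the change (fluoro in place of hydrogen on an aromatic carbon), a fluoro in place of hydrogen on an aromatic carbon of a six-membered aromatic ring of carbon only, part of a fused system of two rings, ortho to a fused ring, meta to a fused ring and meta to a large group. Among the measured compounds shown here, none of the measured steps touches that ring; all three vary the amine nitrogen, so no measured step bears directly on this change. For the measured compounds named here, with no precedent in the set, a step in this assay beyond the scatter is not expected in either direction. Compound 4 is therefore estimated at 0.12 nM, range 0.04 nM to 0.4 nM, which means an expected step of a 1.2-fold higher number from compound 2 to compound 4 (0.08 log units; within the scatter).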

Compound 4, inhibition constant: 0.251 nM
Compound 4: middle estimate off by 2.1-fold (0.32 log units), on the low side; measured number inside the range.
By their numbers in this assay, from the lowest: compounds 2, 3 and 4 (each within the scatter of the next, the first and the last beyond it); then compound 1.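

In this assay the ring that carries the sulfonyl group is now shown to matter: fluoro in place of hydrogen on this aromatic carbon, ortho to a fused ring and meta to a large group, gives a 2.5-fold higher number from compound 2 to compound 4 (0.40 log units; beyond the scatter) and so is not a silent change. The step is modest, and it is known only with the (hydroxymethyl)carbonyl group on the amine nitrogen. No measurement shown here accounts for the step.

As far as these compounds go, whether the step carries over when sulfamoyl or methoxycarbonyl stands on the amine nitrogen remains open. Also open, from the compounds shown here alone, is how chloro, methyl or methoxy would compare with fluoro on this carbon, and whether fluoro on the other carbons of this ring would give a step of similar size.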